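The compounds below may be only part of what the source reports. "The series", "measured", "known", "first", "only" and "open" are said of these compounds alone.

In a functional assay on A549 cells (Homo sapiens) for antiproliferative activity (on this read-out lower numbers stand for an effect already at smaller amounts and higher numbers for an effect only at larger amounts of compound), compound 1 `CCCCCCCO/N=C/c1cc(OC)c2c(c1OC)C(=O)C=CC2=O` gives only a limit, > 10 ug/mL. In this assay compound 2 `CO/N=C/c1cc(OC)c2c(c1OC)C(=O)C=CC2=O` likewise gives only a limit, > 10 ug/mL. The step that the two limits leave unreadable from compound 1 to compound 2 is thus not readable in size, and compound 2 stands at the limit of > 10 ug/mL in this assay, at which 2 of the 2 values shown sit. Compound 3 `CCCCCO/N=C/c1cc(OC)c2c(c1OC)C(=O)C=CC2=O` differs from compound 2 by butyl in place of hydrogen on a saturated chain carbon bound to an oxygen on an unsaturated carbon. Among the measured compounds shown here, no measured step bears readably on this change, so no shift beyond the scatter is expected. The estimated step that the limit leaves unreadable from compound 2 to compound 3 is accordingly taken as flat. For compound 3 the estimated value in this assay is 15 ug/mL, with a range from 8 ug/mL to 40 ug/mL, most likely again returned as a limit.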

Compound 3, concentration for half-maximal effect: > 10 ug/mL
Compound 3 was reported as a limit (the forecaster's own chance of this, stated with the estimate: 75%); the middle value is on the limit's open side.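

Compound 1, compound 2 and compound 3 all return only limits in this assay, so no step among them can be read: the limit of > 10 ug/mL in this assay, at which 3 of the 3 values shown sit.

The compounds shown leave open whether chain length changes the effect in this assay at all.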